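The source may hold more compounds than are shown below. What is called first, only, known or untested is meant among the compounds shown, and "the series" means these compounds.

Compound 1 `Cc1ccc(-c2nn(-c3ccccc3)cc2-c2nc3ccccc3n2S(=O)(=O)c2ccc(F)cc2)cc1` was examined in an ADME assay on cells (Hepatocyte, Mus musculus) for cytotoxicity, read by MTT assay, with a stated time of 24 h (on this read-out lower numbers stand for higher toxicity in this test and higher numbers for lower toxicity in this test), where compound 1 gives 167000 nM. Compound 2 `Cc1ccc(-c2nn(-c3ccccc3)cc2-c2nc3ccccc3n2S(=O)(=O)c2ccc(Cl)cc2)cc1` differs from it by chloro in place of fluoro on an aromatic carbon, and in this assay compound 2 gives 216000 nM; the step of a 1.3-fold higher number from compound 1 to compound 2 (0.11 log units; within the scatter). Compound 3 `O=S(=O)(c1ccc(F)cc1)n1c(-c2cn(-c3ccccc3)nc2-c2ccc(F)cc2)nc2ccccc21` carries a different core, set apart from the core of compound 1 by fluoro in place of methyl on an aromatic carbon; in this assay compound 3 gives 174000 nM, and the step of a 1.0-fold higher number from compound 1 to compound 3 (0.02 log units; within the scatter). Compound 4 `O=S(=O)(c1ccc(Cl)cc1)n1c(-c2cn(-c3ccccc3)nc2-c2ccc(F)cc2)nc2ccccc21` has not yet been measured in this assay. It differs from compound 3 by chloro in place of fluoro on an aromatic carbon, the same change as that from compound 1 to compound 2, made at a place described in the same terms. Because a 1.3-fold higher number from compound 1 to compound 2 (0.11 log units; within the scatter) the same exchange is expected to move compound 4 little: the step of a 1.3-fold higher number from compound 3 to compound 4 (0.11 log units; within the scatter) is estimated. On that basis compound 4 is expected to give about 225000 nM in this assay, most likely between 130000 nM and 390000 nM.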

Compound 4, half-maximal cytotoxic concentration: 231000 nM
Compound 4: middle estimate off by 1.0-fold (0.01 log units), on the low side, and the stated range covers the measured number.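

In this assay the exchange of (4-fluorophenyl)sulfonyl for (4-chlorophenyl)sulfonyl gives a 1.3-fold higher number from compound 3 to compound 4 (0.12 log units; within the scatter), and this agrees with the step seen on the other core: the same change on two cores in this assay, a 1.3-fold higher number (0.11 log units; within the scatter) from compound 1 to compound 2 and a 1.3-fold higher number (0.12 log units; within the scatter) from compound 3 to compound 4, 1.0-fold (0.01 log units) apart, within the scatter of two such steps. The exchange of fluoro for methyl, now read with chloro in place, gives a 1.1-fold higher number from compound 2 to compound 4 (0.03 log units; within the scatter), and it also agrees with its earlier counterpart: the same change on two cores in this assay, a 1.0-fold higher number (0.02 log units; within the scatter) from compound 1 to compound 3 and a 1.1-fold higher number (0.03 log units; within the scatter) from compound 2 to compound 4, 1.0-fold (0.01 log units) apart, within the scatter of two such steps. Within the data shown here, both changes therefore carry from one core to the other across these four compounds, but every step lies within the scatter, so the agreement shows only that neither change gives a measurable shift on either core, not that an effect of fixed size is being transferred.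

Going by these compounds, whether an amine or a carboxylic acid on the same aromatic carbon would behave in the same way remains open. Also open, on these data alone, is whether a step beyond the scatter would carry between these cores, as none of the four compounds shows one.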